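Nitro for Fluoro on the Aryloxymethyl Ketone Tail

The source may hold more compounds than are shown below. What is called first, only, known or untested is meant among the compounds shown, and "the series" means these compounds.

Measured compounds:
compound 1, `CC(C)[C@H](NC(=O)COc1cccc2ccccc12)C(=O)N[C@@H](CC(=O)O)C(=O)COC(=O)c1c(Cl)cccc1Cl`: 10600 nM
compound 2, `CC(C)[C@H](NC(=O)COc1cccc2ccccc12)C(=O)N[C@@H](CC(=O)O)C(=O)COc1ccc2ccccc2c1`: > 100000 nM
compound 3, `CC(C)[C@H](NC(=O)COc1cccc2ccccc12)C(=O)N[C@@H](CC(=O)O)C(=O)COc1ccc(F)cc1F`: 33200 nM

In a functional assay on Jurkat cells (Homo sapiens) (on this read-out lower numbers stand for stronger inhibition and higher numbers for weaker inhibition), compound 1 gives 10600 nM. Compound 2 reaches only a limit of the assay, > 100000 nM, and the limit of > 100000 nM in this assay, at which 1 of the 3 values shown sits, marks it. Compound 3 gives 33200 nM and stands highest of the two numbers shown, with compound 1 nearest. The steps of a 3.1-fold higher number from compound 1 to compound 3 (0.50 log units; beyond the scatter) and an at least 3.0-fold lower number from compound 2 to compound 3 (0.47 log units; beyond the scatter) frame this position, and an at least 9.4-fold higher number from compound 1 to compound 2 (0.97 log units; beyond the scatter) reaches the limit.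

Compound 4, `CC(C)[C@H](NC(=O)COc1cccc2ccccc12)C(=O)N[C@@H](CC(=O)O)C(=O)COc1ccc([N+](=O)[O-])cc1F`, differs from compound 3 by nitro in place of fluoro on an aromatic carbon. Among the compounds with values here, no measured step exchanges a nitro for a fluoro, so the expectation for compound 4 rests on compound 3 alone, and a step of a 1.1-fold lower number from compound 3 to compound 4 (0.04 log units; within the scatter) is expected, within the scatter. Compound 4 is estimated at 30000 nM, between 10000 nM and 100000 nM.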

Compound 4, half-maximal inhibitory concentration: 30300 nM
Beside the measured number, compound 4's estimate is 1.0-fold (0.00 log units) below it; the measured number falls inside the stated range.
By their numbers in this assay, from the lowest: compound 1; then compounds 4 and 3 (each within the scatter of the next). At a limit, above all of these: compound 2.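

Nitro and fluoro on the aromatic carbon para to a large group read alike in this assay (a 1.1-fold lower number from compound 3 to compound 4 (0.04 log units; within the scatter)), so this position accepts three heavy atoms and two hydrogen-bond acceptors in place of one fluorine without a step beyond the scatter. The 2-fluoro-4-nitrophenyl tail still falls short of the ester of compound 1, with a 2.9-fold higher number from compound 1 to compound 4 (0.46 log units; beyond the scatter), and improves on the naphthalen-2-yl tail, with an at least 3.3-fold lower number from compound 2 to compound 4 (0.51 log units; beyond the scatter). Compound 2 remains a limit of the assay: the limit of > 100000 nM in this assay, at which 1 of the 4 values shown sits.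

The compounds shown leave open whether an amine, a nitrile or a carboxylic acid on this carbon would read alike. They also leave open what the remaining fluoro group contributes to the tail.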